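From methylsulfanyl to trifluoromethyl: a step against a limit

This account rests on a few compounds, and the source may have more. Where it says the series, first, only, none or still open, it means among the compounds named here.

Compound 1 `CSc1ccc(NC(=O)Nc2cc(C)nc3ccccc23)cc1`: > 25000 nM
Compound 2 `Cc1cc(NC(=O)Nc2ccccc2C(C)(C)C)c2ccccc2n1`: > 25000 nM

In an ADME assay on Raji cells (Homo sapiens) for cytotoxicity, with a stated time of 72 h (on this read-out lower numbers stand for an effect already at smaller amounts and higher numbers for an effect only at larger amounts of compound), compound 1 gives > 25000 nM, which is a limit and not a number. Compound 2 gives > 25000 nM, also a limit. Compound 3 `Cc1cc(NC(=O)Nc2ccc(C(F)(F)F)cc2)c2ccccc2n1` has trifluoromethyl in place of methylsulfanyl on an aromatic carbon, para to a large group (trifluoromethyl in place of methylsulfanyl on an aromatic carbon). Within the data shown here, no measured pair shows this change on its own. Among the measured compounds shown here, the only guide is the limit of > 25000 nM in this assay, at which 2 of the 2 values shown sit, shared by compound 1 and compound 2, so no step beyond the scatter is expected in this assay. The expected step is a number no higher from compound 1 to compound 3 (the limit leaves the size open). Compound 3 is estimated at 25000 nM, with an expected range from 10000 nM to 50000 nM.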

Compound 3, half-maximal effective concentration: 23000 nM
The estimate for compound 3 lay 1.1-fold (0.04 log units) above the measured number, and the stated range covers the measured number.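

With trifluoromethyl at this place, compound 3 gives a real number in this assay, 23000 nM, the only one among these compounds. The value of compound 1 remains a limit. The change can therefore be read only as an at least 1.0-fold lower number from compound 1 to compound 3 (0.03 log units; that floor lies within the scatter), so the true size of the step could be small or large.

On these data alone, whether an amine or a carboxylic acid on the same aromatic carbon would give a clearly different number stays open. So does the real value of compound 1, and with it how much this change matters.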